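The compounds below may be only part of what the source reports. "The series", "measured", "known", "first", "only" and "open" are said of these compounds alone.

Among the compounds with values here, compound 2 `C=C1C2=C(C(=O)N1OC)[C@H](OC(=O)CCCCCl)[C@@](C)(O)[C@H](CCCCC)O2` is one of two compounds measured in a functional assay on PC-3 cells (Homo sapiens) for cytotoxicity, read by MTT assay, with a stated time of 72 h (on this read-out lower numbers stand for stronger inhibition and higher numbers for weaker inhibition), where compound 2 gives 9200 nM. It stands at the lowest of the two numbers; its nearest neighbour is compound 1 `C=C1C2=C(C(=O)N1OC)[C@H](O)[C@@](C)(O)[C@H](CCCCC)O2`, which in this assay gives 32000 nM. Within the data shown here, the one step between measured compounds is a 3.5-fold lower number from compound 1 to compound 2 (0.54 log units; beyond the scatter), which comes from placing (4-chlorobutyl)carbonyl in place of hydrogen on an oxygen on a saturated carbon.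

Compound 3 `C=C1C2=C(C(=O)N1OC)[C@H](OC(=O)CCl)[C@@](C)(O)[C@H](CCCCC)O2` keeps that ester but shortens it: chloro in place of 3-chloropropyl on a saturated chain carbon bound to a carbonyl carbon. Among the measured compounds shown here, no measured step addresses a change of this kind, since the only step recorded alters the oxygen on the saturated carbon rather than the chain on the carbonyl carbon. The step from compound 1 to compound 2 shows that an ester at this position is tolerated, but it says nothing about how long the chain beside the carbonyl must be. Compound 3 is therefore expected to lie near compound 2, with a step of a 1.2-fold higher number from compound 2 to compound 3 (0.08 log units; within the scatter) that stays within the scatter. For compound 3 the estimate in this assay is 11000 nM, with a range from 4000 nM to 30000 nM.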

Compound 3, half-maximal inhibitory concentration: 2400 nM
Compound 3: the middle estimate sits 4.6-fold (0.66 log units) above what was measured; measured number outside the range, below it.
By their numbers in this assay, from the lowest: compound 3; then compound 2; then compound 1.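

In this assay, the chain on the ester proves to matter and not only the presence of an ester: chloro in place of 3-chloropropyl on a saturated chain carbon bound to a carbonyl carbon gives a further drop (a 3.8-fold lower number from compound 2 to compound 3 (0.58 log units; beyond the scatter)). Measured against the free hydroxyl of compound 1, the (chloromethyl)carbonyl group therefore brings a large step (a 13-fold lower number from compound 1 to compound 3 (1.12 log units; beyond the scatter)), whereas the (4-chlorobutyl)carbonyl group brought only a modest one (a 3.5-fold lower number from compound 1 to compound 2 (0.54 log units; beyond the scatter)). Within these two esters the shorter chain goes with the lower number, though two chain lengths make a comparison rather than a trend, and nothing measured here offers a reason for the difference.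

Both esters end in chlorine, so the compounds shown cannot separate the length of the chain from the presence of the halogen; a plain acetyl ester, with hydrogen in place of the chloro, would bear on that. Going by these compounds, it also remains open whether the number keeps falling or turns at other chains, such as a chloroethyl group, or with an amine at the chain end in place of the chlorine.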